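This account rests on a few compounds, and the source may have more. Where it says the series, first, only, none or still open, it means among the compounds named here.

Working notes on the series. The measured compounds are two. Compound 1 `Cc1nc(-c2ccccc2)c(C(=O)N2CCN(c3cccc(Cl)c3Cl)CC2)o1` carries a 2,3-dichlorophenyl on the ring amine nitrogen, and in a functional assay on HL-60 cells (Homo sapiens) for inhibition, read by MTT assay, with a stated time of 72 h (on this read-out higher numbers stand for weaker inhibition and lower numbers for stronger inhibition), compound 1 gives 133 nM. Compound 2 `CCc1nc(-c2ccccc2Cl)c(C(=O)N2CCN(c3cccc(Cl)c3)CC2)o1` differs in several places at once, and in this assay compound 2 gives 98.9 nM. Going by the values given here, compound 1 stands with compound 2 inside the usual scatter of the method; the two numbers do not separate, and no single-point step between measured compounds exists in these data, so nothing has yet been learned about what a change at the aryl on the piperazine does here.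

The next compound, compound 3 `Cc1nc(-c2ccccc2)c(C(=O)N2CCN(c3ccccc3C(F)(F)F)CC2)o1`, differs from compound 1 in one place: 2-(trifluoromethyl)phenyl in place of 2,3-dichlorophenyl on an amine nitrogen in a ring. Among the compounds with values here, with no comparable step measured, the expectation rests on the numbers of compound 1 and compound 2 alone, and the step from compound 1 to compound 3 is expected to be small, a 1.1-fold higher number from compound 1 to compound 3 (0.05 log units; within the scatter), with no direction beyond the scatter. On that basis compound 3 is estimated at 150 nM, with a range from 50 nM to 450 nM in this assay.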

Compound 3, half-maximal inhibitory concentration: 120 nM
Compound 3: middle estimate off by 1.3-fold (0.10 log units), on the high side; low and high end bracket the measured number.
By their numbers in this assay, from the lowest: compounds 2, 3 and 1 (each within the scatter of the next).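

Going by these compounds alone, this is the first single-point step, and it falls on the aryl on an amine nitrogen in a ring: 2-(trifluoromethyl)phenyl in place of 2,3-dichlorophenyl gives a 1.1-fold lower number from compound 1 to compound 3 (0.04 log units; within the scatter) in this assay. Compound 1 and compound 3 therefore do not separate on this read-out, even though the entering group has 10 heavy atoms against 8 for the group it replaces, so this one swap between two substituted phenyls, each with no hydrogen-bond donors or acceptors and no net charge, leaves the number inside the scatter. No measurement in hand bears on why the two compounds read alike.

The compounds shown carry only chlorine or trifluoromethyl on this aryl, so it stays open whether an amine, a carboxylic acid or a methoxy group on the phenyl, or a simple alkyl chain in place of the phenyl, would move the number beyond the scatter. Compound 2 differs from the others in several places at once, so the contributions of its ethyl group and its chlorine-bearing phenyl also remain unresolved.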